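This account rests on a few compounds, and the source may have more. Where it says the series, first, only, none or still open, it means among the compounds named here.

Of the compounds shown here, two sharing one core have been measured in a functional assay for agonist activity at G protein-coupled receptor 88 (Homo sapiens), read by HTRF and cAMP accumulation; a lower number here means that less compound is needed, a higher number that more compound is needed for the effect. Compound 1, `CC(C)(C)[C@H](N)CN(C(=O)[C@@H]1C[C@H]1c1ccccc1)c1ccc(-c2ccccc2)cc1`, gives 11 nM in this assay. Compound 2, `CC[C@H](C)[C@H](N)CN(C(=O)[C@@H]1C[C@H]1c1cccc(F)c1)c1ccc(-c2ccccc2)cc1`, gives 560 nM in this assay, the higher of the two numbers, and the gap to compound 1 lies beyond the scatter, so compound 2 currently sits at the weaker end of what is known. Compound 3, `CC[C@H](C)[C@H](N)CN(C(=O)[C@@H]1C[C@H]1c1cc(F)ccc1F)c1ccc(-c2ccccc2)cc1`, has not yet been measured. It differs from compound 2 by fluoro in place of hydrogen on an aromatic carbon. Among the compounds with values here, no pair of measured compounds shows this exact change, so there is no step on record to lean on; the only available comparison, compound 1 against compound 2, changes two places at once and cannot be read as a step for this change alone. Without such a step, only a small shift in either direction is expected, most likely none beyond the scatter, and the step from compound 2 to compound 3 is estimated as a 1.4-fold lower number from compound 2 to compound 3 (0.15 log units; within the scatter). Compound 3 is therefore expected to give about 400 nM in this assay, within a range from 120 nM to 1500 nM.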

Compound 3, half-maximal effective concentration: 770 nM
Compound 3: the middle estimate sits 1.9-fold (0.28 log units) below what was measured, and the stated range covers the measured number.
By their numbers in this assay, from the lowest: compound 1; then compounds 2 and 3 (each within the scatter of the next).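

Adding a fluoro group at this position, which turns 3-fluorophenyl into 2,5-difluorophenyl, gives a 1.4-fold higher number from compound 2 to compound 3 (0.14 log units; within the scatter) in this assay, a step that stays within the scatter. Within the data shown here, this is the first comparison here in which only one place changes, so it shows that, at least on the core of compound 2, a fluoro ortho to a large group and para to a fluoro group leaves the number without a readable shift, whereas compound 1 against compound 2 changes two places at once and could say nothing about this position. No supporting measurement bears on this result, so the step stands as a plain observation without an explanation.

On these data alone, whether a larger group at the same position, such as a chloro, a methyl or a methoxy group, would also leave the number in place remains open. Also open, as far as these compounds go, is whether the same fluoro would give an equally small step on the core of compound 1, which gives 11 nM in this assay and so starts from a much lower number.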